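Trading 1,2-thiazol-5-yl for 1,3-thiazol-4-yl

This account rests on a few compounds, and the source may have more. Where it says the series, first, only, none or still open, it means among the compounds named here.

- compound 1 `O=C(O)c1cc(-c2ccns2)ccc1O` gives > 80 mg/kg (a limit)
- compound 2 `O=C(O)c1ccc(-c2cscn2)cc1O` gives > 80 mg/kg (a limit)

Both results come from a functional assay on the whole organism with Rattus norvegicus as the target (on this read-out higher numbers stand for an effect only at larger amounts of compound and lower numbers for an effect already at smaller amounts), and neither is an exact dose. For compound 1 the result > 80 mg/kg is a limit of the assay. For compound 2 the result > 80 mg/kg is also a limit. Among the compounds with values here, the picture so far is therefore (the limit of > 80 mg/kg in this assay, at which 2 of the 2 values shown sit), and no step between two measured compounds exists yet.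

Compound 3 (`O=C(O)c1cc(-c2cscn2)ccc1O`) has not been measured. It keeps the core of compound 1 and exchanges one group, with 1,3-thiazol-4-yl in place of 1,2-thiazol-5-yl on an aromatic carbon. The new ring sits where the old one did, meta to a carboxy group and para to a hydroxy group.

Compound 1 offers only its limit > 80 mg/kg as a starting point, so no step beyond the usual scatter is expected in this assay, in either direction. The estimated change is a number no higher from compound 1 to compound 3 (the limit leaves the size open). For compound 3 the expected value is 80 mg/kg, within an estimated range of 30 mg/kg to 160 mg/kg.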

Compound 3, dose for half-maximal effect: 90 mg/kg
Compound 3: middle estimate off by 1.1-fold (0.05 log units), on the low side, within the range that was stated.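

No step from compound 1 to compound 3 can be read, because the result for compound 1 is a limit of the assay and not an exact dose: the limit of > 80 mg/kg in this assay, at which 2 of the 3 values shown sit.

The compounds shown leave open what exact dose compound 1 would need, and so whether 1,3-thiazol-4-yl in place of 1,2-thiazol-5-yl changes the dose at all.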